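The compounds below may be only part of what the source reports. "The series", "measured", "known", "first", "only" and "open" are said of these compounds alone.

Compound 1 `Cn1cnnc1SCC(=O)Nc1ccc(-c2nc(-c3ccccc3)c(-c3ccccc3)n2C)cc1` gives 89.3% in a functional assay on MCF7 cells (Homo sapiens) for cytotoxicity, read by MTT assay, with a stated time of 24 h, tested at 80 ug/mL (a lower number here means a weaker effect, a higher number a stronger effect of the compound at the concentration tested), and stands highest of the two numbers shown, the nearest being compound 2 `Cn1ccnc1SCC(=O)Nc1ccc(-c2nc(-c3ccccc3)c(-c3ccccc3)n2C)cc1`, which in this assay gives 64%. Among the compounds with values here, the one measured step, a number 25.3 percentage points lower from compound 1 to compound 2 (beyond the scatter), came from exchanging the ring on the sulfur and was modest but beyond the scatter. Compound 3 `Cn1c(-c2ccc(NC(=O)CN3CCN(c4ccccc4)CC3)cc2)nc(-c2ccccc2)c1-c1ccccc1` differs from compound 1 by 4-phenylpiperazin-1-yl in place of (4-methyl-4H-1,2,4-triazol-3-yl)sulfanyl on a saturated chain carbon bound to a carbonyl carbon, a larger exchange of the same outer part of the molecule, removing the sulfur and the ring on it altogether. That step from compound 1 to compound 2 is the only one that bears on it, and it suggests that changes at this end lower the read-out. A step downward, perhaps of similar or somewhat larger size, is therefore expected, namely a number 27.3 percentage points lower from compound 1 to compound 3 (beyond the scatter). Compound 3 is estimated at 62%, within the range 32% to 88%.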

Compound 3, a percentage reported as activity, at one concentration (the size of the read-out at that concentration, not a potency): 72.5%
For compound 3 the middle estimate is 10.5 percentage points below the measured one; the measured number falls inside the stated range.
By their numbers in this assay, from the lowest: compounds 2 and 3 (each within the scatter of the next); then compound 1.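

Exchanging (4-methyl-4H-1,2,4-triazol-3-yl)sulfanyl for 4-phenylpiperazin-1-yl on a saturated chain carbon bound to a carbonyl carbon gives, in this assay, a number 16.8 percentage points lower from compound 1 to compound 3 (beyond the scatter), so compound 1 now stands above two different replacements. Against the other replacement, the step is a number 8.5 percentage points higher from compound 2 to compound 3 (within the scatter), and the read-out does not separate 4-phenylpiperazin-1-yl from (1-methyl-1H-imidazol-2-yl)sulfanyl. Among these compounds, then, a sulfur at this place is not required for a read-out at the level of compound 2, although only compound 1 rises beyond the scatter of compound 3.

Nothing at hand accounts for these differences. On these data alone, it remains open whether a morpholine ring, an unsubstituted piperazine or a longer chain at this place would match compound 1 or stay with compounds 2 and 3.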